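The source may report more compounds than this note shows. Statements on the series, on what has been measured and on what is new or still open speak of the compounds shown alone.

Three compounds share one core, shown by compound 1 `Cc1cccc(NC(=O)Nc2cccc(CNc3ncnc4ccccc34)c2)c1`, and differ only in the aromatic group attached to an amide-type nitrogen. In a functional assay on HepG2 cells (Homo sapiens) for antiproliferative activity, read by MTT assay (a higher number here means a weaker inhibitor, a lower number a stronger inhibitor), compound 1 gives only a limit of the assay, > 50000 nM. Compound 2 `O=C(Nc1cccc(CNc2ncnc3ccccc23)c1)Nc1ccccc1F` carries a 2-fluorophenyl group, and in this assay compound 2 gives 17500 nM. Compound 3 `O=C(Nc1ccc(F)cc1)Nc1cccc(CNc2ncnc3ccccc23)c1` carries a 4-fluorophenyl group, and in this assay compound 3 gives 41500 nM, the higher of the two numbers measured; the step of a 2.4-fold higher number from compound 2 to compound 3 (0.38 log units; beyond the scatter) lies beyond the scatter, while the step of an at least 1.2-fold lower number from compound 1 to compound 3 (0.08 log units; that floor lies within the scatter) rests on a limit and has a floor within the scatter.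

Compound 4 `O=C(Nc1ccc([N+](=O)[O-])cc1)Nc1cccc(CNc2ncnc3ccccc23)c1` has not been measured. It differs from compound 3 by nitro in place of fluoro on an aromatic carbon. Within the data shown here, none of the measured steps swaps fluoro for nitro. The steps of an at least 2.8-fold lower number from compound 1 to compound 2 (0.45 log units; beyond the scatter) and a 2.4-fold higher number from compound 2 to compound 3 (0.38 log units; beyond the scatter) exchange one aromatic group for another on the same amide-type nitrogen and move this assay by modest amounts, so a modest step in either direction, or none beyond the scatter, is expected here. The estimated step is a 1.4-fold lower number from compound 3 to compound 4 (0.14 log units; within the scatter). Compound 4 is estimated at 30000 nM, with a range from 8000 nM to 110000 nM.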

Compound 4, half-maximal inhibitory concentration: 24600 nM
Estimate against measurement, compound 4: 1.2-fold (0.09 log units) above; measured number inside the range.
By their numbers in this assay, from the lowest: compounds 2, 4 and 3 (each within the scatter of the next, the first and the last beyond it). At a limit, above all of these: compound 1.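

Replacing fluoro with nitro on this aromatic carbon, para to a large group, adds heavy atoms and hydrogen-bond acceptors, yet this assay shows a 1.7-fold lower number from compound 3 to compound 4 (0.23 log units; within the scatter), so this change makes no difference that can be told from the scatter. The earlier compounds shown here left a gap beyond the scatter between the 2-fluorophenyl and 4-fluorophenyl groups, but the 4-nitrophenyl group does not separate from the 2-fluorophenyl group, with a 1.4-fold higher number from compound 2 to compound 4 (0.15 log units; within the scatter), and compound 4 lies within the scatter of both compound 2 and compound 3. The comparison with the 3-methylphenyl group is less firm, as an at least 2.0-fold lower number from compound 1 to compound 4 (0.30 log units; that floor lies within the scatter) gives only a floor and compound 1 has a limit rather than a number: the limit of > 50000 nM in this assay, at which 1 of the 4 values shown sits.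

As far as these compounds go, with only fluoro and nitro compared on this carbon, it remains open whether an amine or a carboxylic acid there would move the number beyond the scatter. From the compounds shown here alone, it also remains open how a nitro group would read in place of the fluoro of compound 2, on the 2-fluorophenyl group.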